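The compounds below may be only part of what the source reports. "The series", "measured", "known", "first", "only" and "open" are said of these compounds alone.

Compound 1 `COc1cc(N2C(N)=C(C#N)C(c3c(OC)ccc4ccccc34)C3=C2CC(C)(C)CC3=O)cc(OC)c1OC`: in a functional assay on Ehrlich cells (Mus musculus) for cytotoxicity, tested at 25 ug/mL (on this read-out lower numbers stand for a weaker effect and higher numbers for a stronger effect at the one concentration tested), compound 1 gives 5%.
Compound 2 `COc1cc(N2C(N)=C(C#N)C(c3c(O)ccc4ccccc34)C3=C2CC(C)(C)CC3=O)cc(OC)c1OC`: in this assay compound 2 gives 10%.

Compound 2 holds the higher of the two numbers, but the step of a number 5 percentage points higher from compound 1 to compound 2 (within the scatter) lies within the scatter, so the two compounds cannot be told apart. Compound 3 `COc1cc(N2C(N)=C(C#N)C(c3cccc([N+](=O)[O-])c3)C3=C2CC(C)(C)CC3=O)cc(OC)c1OC` differs from compound 2 at one place: 3-nitrophenyl in place of 2-hydroxynaphthalen-1-yl on a saturated ring carbon. Among the compounds with values here, the single measured step concerns only a methyl on an oxygen, not an exchange of the whole aromatic group, so it does not bear directly on this change; the only guide is that both measured numbers are low. No step beyond the scatter is therefore expected in this assay. Compound 3 is estimated at 8%, with a range from 0% to 25%. This expectation amounts to a step of a number 2 percentage points lower from compound 2 to compound 3 (within the scatter).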

Compound 3, a percentage reported as activity, at one concentration (the size of the read-out at that concentration, not a potency): 20%
Compound 3: middle estimate off by 12 percentage points, on the low side; low and high end bracket the measured number.
By their numbers in this assay, from the lowest: compounds 1, 2 and 3 (each within the scatter of the next, the first and the last beyond it).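

In this assay, within the data shown here, exchanging the whole aromatic group on the saturated ring carbon gives the first change beyond the scatter: 3-nitrophenyl in place of 2-methoxynaphthalen-1-yl gives a number 15 percentage points higher from compound 1 to compound 3 (beyond the scatter). The same position with 2-hydroxynaphthalen-1-yl leaving gives a number 10 percentage points higher from compound 2 to compound 3 (within the scatter), so only one of the two naphthalene compounds separates from compound 3. Nothing measured here explains the modest step.

The compounds shown leave open whether the nitro group or the change from two aromatic rings to one matters more. A plain phenyl group or a 3-aminophenyl group at this position could separate those two changes.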